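Compound 4: oxetan-3-yl in place of (oxetan-3-yl)carbonyl

The source may report more compounds than this note shows. Statements on the series, on what has been measured and on what is new or still open speak of the compounds shown alone.

Of the compounds shown here, three have been read in a physicochemical assay for solubility, read by chemiluminescence, measured as kinetic solubility (a higher number here means a more soluble compound, a lower number a less soluble compound), and none of them gives a plain number. Compound 1 `CC(=O)NCc1cccc(Cn2nc(NS(=O)(=O)c3ccc(Cl)s3)c3ccccc32)c1` gives >= 117 ug/mL, which is a limit. Compound 2 `CC(=O)NCc1cccc(Cn2nc(NS(=O)(=O)c3ccc(Cl)s3)c3c(CO)cccc32)c1` gives >= 113 ug/mL, also a limit. Compound 3 `COc1cccc2c1c(NS(=O)(=O)c1ccc(Cl)s1)nn2Cc1cccc(CNC(=O)C2COC2)c1` gives >= 173 ug/mL, again a limit. Compound 3 therefore stands with the other two, and no true number places it among them.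

Compound 4 `COc1cccc2c1c(NS(=O)(=O)c1ccc(Cl)s1)nn2Cc1cccc(CNC2COC2)c1` has oxetan-3-yl in place of (oxetan-3-yl)carbonyl on an amine nitrogen. Among the compounds with values here, the only measured step, a step that the two limits leave unreadable from compound 1 to compound 2, puts hydroxymethyl in place of hydrogen on an aromatic carbon, so it gives no size to carry over. Within the data shown here, no measured step touches the amine nitrogen.

The expectation rests on compound 3, whose limit of >= 173 ug/mL is the closest reading available. No change beyond the scatter is expected, and the estimated step is an at least 1.1-fold lower number from compound 3 to compound 4 (0.06 log units; that floor lies within the scatter). For compound 4 the expected value in this assay is 150 ug/mL, with an estimated range from 70 ug/mL to 230 ug/mL.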

Compound 4, solubility: 122 ug/mL
For compound 4 the middle estimate is 1.2-fold (0.09 log units) above the measured one; the range from low to high includes it.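

In this assay compound 4 is the only compound shown that gives a plain number rather than a limit, and its change is the first shown on this amine nitrogen that can be read at all. Exchanging (oxetan-3-yl)carbonyl for oxetan-3-yl gives an at least 1.4-fold lower number from compound 3 to compound 4 (0.15 log units; that floor lies within the scatter), so the compounds show no change beyond the usual scatter, though the step may be larger than this floor. Its true size stays unknown because compound 3 stands at a limit of the assay: the limit of >= 173 ug/mL in this assay, at which 1 of the 4 values shown sits.

The compounds shown leave open whether the real step from the amide to the amine goes beyond the scatter. They also leave open how a methyl group, a longer alkyl chain or a carboxylic acid on the same amine nitrogen would read in this assay.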